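Chloro on compound 2, among solubility limits

This account rests on a few compounds, and the source may have more. Where it says the series, first, only, none or still open, it means among the compounds named here.

Compound 2 `CN(Cc1ccccc1)c1cc(C(=O)Nc2ccccc2)ncn1` has no exact number in a physicochemical assay for solubility, using the shake flask method, measured as kinetic solubility, with a stated time of 2 h, at pH 7.4 (on this read-out lower numbers stand for lower solubility and higher numbers for higher solubility), to start from. Compound 2 gives < 5000 nM as a limit of the assay and not a number. Compound 1 `COc1ccc(NC(=O)c2cc(N(C)Cc3ccccc3)ncn2)cc1` gives < 5000 nM as a limit too. Compound 3 `CN(Cc1ccc(C(F)(F)F)cc1)c1cc(C(=O)Nc2ccccc2)ncn1` gives < 5000 nM as a limit as well. All three therefore share one reading, the limit of < 5000 nM in this assay, at which 3 of the 3 values shown sit, and nothing finer.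

Compound 4 `CN(Cc1cccc(Cl)c1)c1cc(C(=O)Nc2ccccc2)ncn1` differs from compound 2 by chloro in place of hydrogen on an aromatic carbon and so carries 3-chlorobenzyl in place of benzyl. The nearest measured change is a step that the two limits leave unreadable from compound 2 to compound 3 with trifluoromethyl in place of hydrogen on an aromatic carbon. The other is a step that the two limits leave unreadable from compound 1 to compound 2 with hydrogen in place of methoxy. Neither gives a size to carry over, so no direction can be expected. The expected change is a step that the limit leaves unreadable from compound 2 to compound 4 and this estimate implies nothing beyond the usual scatter. Compound 4 is estimated at 3000 nM with an expected range from 1000 nM to 5000 nM and will most likely be reported as a limit again.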

Compound 4, solubility: < 5000 nM
Compound 4: a limit, no number (the forecaster's own chance of this, stated with the estimate: 90%); the middle value is on the limit's open side.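

No step can be read from compound 2 to compound 4, as compound 1, compound 2, compound 3 and compound 4 all share one reading: the limit of < 5000 nM in this assay, at which 4 of the 4 values shown sit.

The compounds shown leave open whether chloro, trifluoromethyl or methoxy shifts the true solubility in this assay at all, and in which direction.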